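Solubility notes on the 1-acetylpiperidin-4-yl replacement

The source may report more compounds than this note shows. Statements on the series, on what has been measured and on what is new or still open speak of the compounds shown alone.

Measured compounds in a physicochemical assay for solubility, read by nephelometry, at pH 7.4; a lower number here means a less soluble compound, a higher number a more soluble compound:
Compound 1 `COc1cccc(NC(=O)c2nnn(CC3CCN(C(C)=O)CC3)c2N)c1` gives > 250000 nM, which is a limit of the assay rather than a number.
Compound 2 `COc1cccc(NC(=O)c2nnn(Cc3ccccc3)c2N)c1` gives 16000 nM.

Compound 1 therefore stands only at a limit in this assay, (the limit of > 250000 nM in this assay, at which 1 of the 2 values shown sits). The change to compound 3 `COc1cccc(NC(=O)c2nnn(Cc3ccc(C4CC4)cc3)c2N)c1` is 4-cyclopropylphenyl in place of 1-acetylpiperidin-4-yl on a saturated chain carbon bound to an aromatic nitrogen. Within the data shown here, the single measured step that bears on it, an at least 15-fold lower number from compound 1 to compound 2 (1.19 log units; beyond the scatter), is large and beyond the scatter. A downward step of at least that size is expected here, an at least 50-fold lower number from compound 1 to compound 3 (1.69 log units; beyond the scatter). Compound 3 is estimated at 5000 nM in this assay, with a range from 1000 nM to 25000 nM.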

Compound 3, solubility: 79000 nM
Compound 3: the middle estimate sits 16-fold (1.20 log units) below what was measured; measured number outside the range, above it.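

In this assay the change to 4-cyclopropylphenyl gives an at least 3.1-fold lower number from compound 1 to compound 3 (0.50 log units; beyond the scatter). That step is only a floor, because compound 1 stands at a limit of the assay: the limit of > 250000 nM in this assay, at which 1 of the 3 values shown sits.

The new information is the step on the aromatic carbon: cyclopropyl in place of hydrogen gives a 4.9-fold higher number from compound 2 to compound 3 (0.69 log units; beyond the scatter), so this position can move the number upward as well.

As far as these compounds go, whether this rise is particular to cyclopropyl stays open, since a methyl, a longer chain or an amine on that aromatic carbon could move the number differently. From the compounds shown here alone, how far compound 1 lies past its limit also stays open.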